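The source may hold more compounds than are shown below. What is called first, only, known or untested is meant among the compounds shown, and "the series" means these compounds.

Measured compounds:
compound 1, `Cc1cccc(-c2nc(C(F)(F)F)n(CC[C@@H](O)C[C@@H](O)CC(=O)O)c2-c2ccc(F)cc2)c1`, 29 nM
compound 2, `O=C(O)C[C@H](O)C[C@H](O)CCn1c(C(F)(F)F)nc(-c2ccc(F)cc2)c1-c1cccc(Cl)c1`, 41 nM

Both compounds were tested in an assay on microsomes from liver for inhibition of 3-hydroxy-3-methylglutaryl-coenzyme A reductase (Rattus norvegicus); a higher number here means a weaker inhibitor, a lower number a stronger inhibitor. Compound 1 gives 29 nM, and compound 2 gives 41 nM. Of the two numbers, compound 2 carries the higher one, but the gap to compound 1 lies within the scatter of repeated measurements, so the two cannot be told apart on these data.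

Compound 3, `Cc1ccc(-c2c(-c3ccc(F)cc3)nc(C(F)(F)F)n2CC[C@@H](O)C[C@@H](O)CC(=O)O)cc1`, has not yet been measured in this assay. It differs from compound 2 in one place: 4-methylphenyl in place of 3-chlorophenyl on an aromatic carbon. Going by the values given here, no step between two measured compounds that differ in exactly one place is known here, so there is no direct precedent for swapping one group on that aromatic carbon for another of the same size, and the effect of moving from 3-chlorophenyl to 4-methylphenyl has to be judged without such a reference.

For compound 3 a small rise in the number is expected, with the estimated step of a 1.5-fold higher number from compound 2 to compound 3 (0.17 log units; within the scatter) likely staying within the scatter or only slightly beyond it. The estimated value for compound 3 in this assay is 60 nM, with a range from 20 nM to 200 nM.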

Compound 3, half-maximal inhibitory concentration: 750 nM
Compound 3: middle estimate off by 13-fold (1.10 log units), on the low side; measured number outside the range, above it.
By their numbers in this assay, from the lowest: compounds 1 and 2 (each within the scatter of the next); then compound 3.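

The earlier compounds shown here offered no step at this aromatic carbon, the one next to the ring nitrogen and bearing the aryl group beside the 6-carboxy-3,5-dihydroxyhexyl group in the printed place description. In this assay, the exchange of 3-chlorophenyl for 4-methylphenyl gives an 18-fold higher number from compound 2 to compound 3 (1.26 log units; beyond the scatter), which shows that this position can respond strongly to a change that leaves the heavy-atom count and the six-membered aromatic carbon ring the same. Nothing available here explains the size of this rise.

This single step changes both the substituent's identity and its place on the phenyl ring, so the compounds shown leave open which of the two goes with the rise. A 4-chlorophenyl group on this carbon would separate those two changes, and an unsubstituted phenyl group would show whether the chlorine of compound 2 or the methyl of compound 3 matters more in the comparison.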